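The compounds below may be only part of what the source reports. "The series", "measured", "known", "first", "only" and "open" are said of these compounds alone.

Compounds measured:
compound 1 `Cc1nc(S(C)(=O)=O)ccc1Oc1ncnc(OC2CCN(C(=O)OC3CCC3)CC2)c1F`: 13.6 nM
compound 2 `Cc1nc(S(C)(=O)=O)ccc1Oc1ncnc(OC2CCN(C(=O)c3noc(C(C)C)n3)CC2)c1F`: 21.2 nM

The series shares a core and differs only in the group attached to the carbonyl carbon of the piperidine amide-type nitrogen. In a functional assay on isolated protein for inhibition of Glucose-dependent insulinotropic receptor (Homo sapiens), read by HTRF and cAMP accumulation (on this read-out higher numbers stand for an effect only at larger amounts of compound and lower numbers for an effect already at smaller amounts), compound 1 gives 13.6 nM, and compound 2 gives 21.2 nM, the higher of the two numbers. Within the data shown here, the only step between measured compounds, a 1.6-fold higher number from compound 1 to compound 2 (0.19 log units; within the scatter), is within the scatter, so neither compound can be called the more active on these numbers.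

Compound 3 `CCc1cnc(C(=O)N2CCC(Oc3ncnc(Oc4ccc(S(C)(=O)=O)nc4C)c3F)CC2)nc1` arises from compound 2 by 5-ethylpyrimidin-2-yl in place of 5-isopropyl-1,2,4-oxadiazol-3-yl on a carbonyl carbon. The change replaces one group on the same carbonyl carbon with another of matching size, and the one comparable replacement already measured, from cyclobutyloxy to the oxadiazole, moved the number by a 1.6-fold higher number from compound 1 to compound 2 (0.19 log units; within the scatter), which lies within the scatter. Among the measured compounds shown here, no measured step separates a six-membered aromatic ring from a five-membered one at this position, so the expectation rests on that single replacement. A step of a 1.2-fold lower number from compound 2 to compound 3 (0.07 log units; within the scatter) is therefore expected, that is, no change beyond the scatter. For compound 3 in this assay the estimated value is 18 nM, with a range from 7 nM to 50 nM.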

Compound 3, half-maximal effective concentration: 4.7 nM
Compound 3: middle estimate off by 3.8-fold (0.58 log units), on the high side, and the stated range ends above it.
By their numbers in this assay, from the lowest: compound 3; then compounds 1 and 2 (each within the scatter of the next).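

In this assay, the group on the carbonyl carbon now proves able to move the number beyond the scatter: a 4.5-fold lower number from compound 2 to compound 3 (0.65 log units; beyond the scatter) and a 2.9-fold lower number from compound 1 to compound 3 (0.46 log units; beyond the scatter), whereas a 1.6-fold higher number from compound 1 to compound 2 (0.19 log units; within the scatter) stayed within it. The step from the 5-isopropyl-1,2,4-oxadiazol-3-yl group to the 5-ethylpyrimidin-2-yl group comes with no change in heavy-atom count or net charge, so a difference at this place need not involve a change in either; what does change is a five-membered aromatic ring giving way to a six-membered one, with a different set of hetero atoms and a different alkyl group. Nothing available explains why the number falls with this replacement.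

With ring and alkyl group changing together, the compounds shown cannot tell whether the step belongs to the pyrimidine ring or to its ethyl group. On these data alone, it also remains open whether a pyridine ring, or a pyrimidine ring carrying a methyl group, a propyl chain or an amine in place of the ethyl group, would keep the lower number.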